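Swapping oxolan-2-yl for cyclopentyl on compound 3

The source may hold more compounds than are shown below. What is called first, only, known or untested is meant among the compounds shown, and "the series" means these compounds.

In a functional assay, read by fluorescence and spectrophotometry, with a stated time of 1 h (on this read-out higher numbers stand for an effect only at larger amounts of compound and lower numbers for an effect already at smaller amounts), compound 3 (`O=S(=O)(/C=C/c1ccc(O)c(O)c1)CC1CCCO1`) gives 10500 nM and sits within the usual scatter of both neighbours, since compound 1 (`O=S(=O)(/C=C/c1ccc(O)c(O)c1)CC1CCCCC1`) gives 7500 nM and compound 2 (`O=S(=O)(/C=C/c1ccc(O)c(O)c1)CC1CCCN1`) gives 13800 nM in this assay as well. Compound 4 (`O=S(=O)(/C=C/c1ccc(O)c(O)c1)CC1CCCC1`) has cyclopentyl in place of oxolan-2-yl on a saturated chain carbon bound to a sulfonyl sulfur. Three swaps at this same place are known (a 1.8-fold higher number from compound 1 to compound 2 (0.26 log units; within the scatter) and a 1.4-fold higher number from compound 1 to compound 3 (0.15 log units; within the scatter) and a 1.3-fold lower number from compound 2 to compound 3 (0.12 log units; within the scatter)) and none leaves the scatter. No step beyond the scatter is therefore expected, and the estimate amounts to a 1.1-fold lower number from compound 3 to compound 4 (0.04 log units; within the scatter) in this assay. Compound 4 is expected at 9500 nM (estimated range 5000 nM to 18000 nM).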

Compound 4, half-maximal effective concentration: 9400 nM
Compound 4: middle estimate off by 1.0-fold (0.00 log units), on the high side, within the range that was stated.
By their numbers in this assay, from the lowest: compounds 1, 4, 3 and 2 (each within the scatter of the next).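

In this assay, cyclopentyl in place of oxolan-2-yl gives a 1.1-fold lower number from compound 3 to compound 4 (0.05 log units; within the scatter) and so shows that the ring oxygen, the one hydrogen-bond acceptor of oxolan-2-yl, can be lost at this place without a step beyond the scatter. The carbon-only five-membered ring also stays close to the other two rings, with a 1.5-fold lower number from compound 2 to compound 4 (0.17 log units; within the scatter) and with a 1.3-fold higher number from compound 1 to compound 4 (0.10 log units; within the scatter) as well, so none of the four rings tested here stands apart. Nothing available explains why these swaps make so little difference. As far as these compounds go, whether a carboxylic acid, a longer chain or a phenyl ring at this place would step beyond the scatter stays open.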